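Swapping the distal phenyl for a carboxy on the aryl tail

The source may report more compounds than this note shows. Statements on the series, on what has been measured and on what is new or still open speak of the compounds shown alone.

Measured compounds:
- Compound 1, `O=C(O)CC(O)(CC(=O)CCCCCCc1ccc(Cl)cc1Cl)C(=O)O`: 1200 nM
- Compound 2, `O=C(O)CC(O)(CSCCCCCCc1ccc(-c2ccccc2)cc1)C(=O)O`: 38000 nM

Within the data shown here, in an assay on isolated protein for inhibition of ATP-citrate synthase (Rattus norvegicus) (on this read-out higher numbers stand for weaker inhibition and lower numbers for stronger inhibition), compound 2 gives 38000 nM, the higher of the pair of numbers known so far; compound 1 gives 1200 nM, a much lower number, and this gap lies well beyond the scatter. Among the measured compounds shown here, the two structures differ in several places at once, so no single step between them can be read.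

Compound 3, `O=C(O)CC(O)(CSCCCCCCc1ccc(C(=O)O)cc1)C(=O)O`, is still to be measured. It differs from compound 2 by carboxy in place of phenyl on an aromatic carbon. Nothing measured here tells how such a change acts, so the expectation rests on the weak starting point of compound 2 alone. The step is expected to be small to moderate, most likely toward a higher number, with a real chance of no change beyond the scatter, giving a 1.6-fold higher number from compound 2 to compound 3 (0.20 log units; within the scatter). For compound 3 the estimated value in this assay is 60000 nM, with a range from 15000 nM to 250000 nM.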

Compound 3, inhibition constant: 420000 nM
For compound 3 the middle estimate is 7.0-fold (0.85 log units) below the measured one; the whole stated range lies below it.
By their numbers in this assay, from the lowest: compound 1; then compound 2; then compound 3.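

In this assay carboxy in place of phenyl gives an 11-fold higher number from compound 2 to compound 3 (1.04 log units; beyond the scatter) and thereby shows that what sits on this aromatic carbon, para to a large group, strongly affects the read-out. The change is not a simple swap: it removes a six-membered aromatic ring of carbon only and brings in a smaller group with one hydrogen-bond donor and one hydrogen-bond acceptor. No measurement at hand explains the step.

This single pair cannot show whether the weaker inhibition follows from losing the ring or from gaining the carboxy. A methyl ester or a primary amide at this position could help separate those two readings, and a methyl group would show how a small group without a hydrogen-bond donor fares.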